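Configuration and the acyl group in a hydroxamate series

This account rests on a few compounds, and the source may have more. Where it says the series, first, only, none or still open, it means among the compounds named here.

Measured so far:
- compound 1, `O=C(N[C@@H]1C[C@H](C(=O)NO)N(S(=O)(=O)c2ccc(Cl)c(Cl)c2)C1)c1cccs1`: 95%
- compound 2, `O=C(N[C@H]1C[C@H](C(=O)NO)N(S(=O)(=O)c2ccc(Cl)c(Cl)c2)C1)c1cccs1`: "not active" (no number reported)

In an assay on isolated protein for inhibition of matrix metalloproteinase-9 (Homo sapiens), read by fluorescence, with stated times of 5 min and 30 min, tested at 5 uM (on this read-out higher numbers stand for more inhibition at the one concentration tested (going by the name of the read-out) and lower numbers for less inhibition), compound 1 gives 95%, while compound 2 gives "not active" (no number reported), with no number attached to that result. The two compounds share every atom and bond; the fact that compounds 1 and 2 differ only in the configuration as drawn is the only way in which they part, so compound 2 is reported as not active in this assay, while compound 1 gives the higher number seen so far.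

Compound 3, `O=C(/C=C/c1ccco1)N[C@H]1C[C@H](C(=O)NO)N(S(=O)(=O)c2ccc(Cl)c(Cl)c2)C1`, keeps the configuration of compound 2 and alters only the acyl group: 2-(furan-2-yl)ethenyl in place of thiophen-2-yl on a carbonyl carbon. The change from compound 2 to compound 3 is a swap of one aromatic group for a larger one that carries a double bond outside the ring, while the rest of the molecule stays as in compound 2.

Among the compounds with values here, no measured step between compounds shows how this swap moves this assay. Since compound 2, which carries the same configuration, gives "not active" (no number reported) in this assay, the expectation is for a low reading, though the change could move the value in either direction beyond the scatter. Compound 3 is therefore estimated at 15%, within a range of 0% to 50%.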

Compound 3, a percentage reported as inhibition, at one concentration (the size of the read-out at that concentration, not a potency): 100%
The estimate for compound 3 lay 85 percentage points below the measured number, and the stated range ends below it.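

In this assay, within the data shown here, compound 3 gives 100% while compound 2 carries no number, so no step between compound 2 and compound 3 can be read. Nothing shown accounts for this reading. The compounds shown leave open how much the 2-(furan-2-yl)ethenyl group contributes to it, and how that group would read with the configuration of compound 1.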